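Phenylurea pyrimidine thioindoles: swapping anilino for pyridinylpiperazine

The source may hold more compounds than are shown below. What is called first, only, known or untested is meant among the compounds shown, and "the series" means these compounds.

Compound 1: `COc1ccc(NC(=O)Nc2nc(Sc3c[nH]c4ccccc34)cc(N3CCN(c4ccccn4)CC3)n2)cc1`, 11400 nM
Compound 2: `O=C(Nc1ccccc1)Nc1nc(Nc2ccccc2)cc(Sc2c[nH]c3ccccc23)n1`, 14400 nM

In a functional assay on HepG2 cells (Homo sapiens) for inhibition, with a stated time of 72 h (on this read-out higher numbers stand for weaker inhibition and lower numbers for stronger inhibition), compound 2 gives 14400 nM, the highest of the two numbers, with compound 1 at 11400 nM lying within the scatter of it. Compound 3, `O=C(Nc1ccccc1)Nc1nc(Sc2c[nH]c3ccccc23)cc(N2CCN(c3ccccn3)CC2)n1`, differs from compound 2 by 4-(pyridin-2-yl)piperazin-1-yl in place of anilino on an aromatic carbon. Among the measured compounds shown here, with no measured step of this kind at hand, and both measured numbers close together, no step beyond the scatter is expected in this assay. The step from compound 2 to compound 3 is estimated at a 1.2-fold lower number from compound 2 to compound 3 (0.08 log units; within the scatter). Compound 3 is therefore expected to give about 12000 nM, between 5000 nM and 30000 nM.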

Compound 3, half-maximal inhibitory concentration: 8930 nM
Estimate against measurement, compound 3: 1.3-fold (0.13 log units) above; the range from low to high includes it.
By their numbers in this assay, from the lowest: compounds 3, 1 and 2 (each within the scatter of the next).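

In this assay, 4-(pyridin-2-yl)piperazin-1-yl in place of anilino at this position gives a 1.6-fold lower number from compound 2 to compound 3 (0.21 log units; within the scatter), so this much larger group, which brings a non-aromatic ring, leaves the number within the scatter. Hydrogen in place of methoxy on an aromatic carbon gives a 1.3-fold lower number from compound 1 to compound 3 (0.11 log units; within the scatter), so that change also produces no step beyond the scatter. Nothing available explains these numbers.

From the compounds shown here alone, whether morpholin-4-yl or a simple dimethylamino group at this position would move the number beyond the scatter remains open. The same holds for chlorine or a carboxylic acid in place of methoxy.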